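The compounds below may be only part of what the source reports. "The series", "measured", "known", "first", "only" and "open" are said of these compounds alone.

Measured compounds: compound 1 `CCCCCCCCCCCCOc1ccc(NC(=O)O/N=C/c2ccccc2)cc1` with 2.4 nM; compound 2 `CCCCCCOc1ccc(NC(=O)Oc2ccccc2)cc1` with 31 nM.

In an assay on H4 cells for inhibition of Fatty-acid amide hydrolase 1 (Homo sapiens) (on this read-out lower numbers stand for stronger inhibition and higher numbers for weaker inhibition), compound 2 gives 31 nM, the higher of the two numbers; its gap to compound 1 lies beyond the scatter. Compound 3 `CCCCCCCCCCCCOc1ccc(NC(=O)Oc2ccccc2)cc1` differs from compound 2 by hexyl in place of hydrogen on a saturated chain carbon, six bonds along the chain from an oxygen on an aromatic ring. Among the measured compounds shown here, no measured step of this kind exists, so the expectation rests on the two numbers alone. Since compound 1 gives 2.4 nM with the longer chain, the step is estimated to lower the number beyond the scatter, as a 3.9-fold lower number from compound 2 to compound 3 (0.59 log units; beyond the scatter). Compound 3 is accordingly expected near 8 nM, with a range from 2 nM to 30 nM.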

Compound 3, half-maximal inhibitory concentration: 1.8 nM
Estimate against measurement, compound 3: 4.4-fold (0.65 log units) above; measured number outside the range, below it.
By their numbers in this assay, from the lowest: compounds 3 and 1 (each within the scatter of the next); then compound 2.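

In this assay hexyl in place of hydrogen on a saturated chain carbon, six bonds along the chain from an oxygen on an aromatic ring, brings a large change (a 17-fold lower number from compound 2 to compound 3 (1.24 log units; beyond the scatter)), which compound 1 and compound 2, differing in two places, could not isolate. With the chain the same, the change of group on the oxygen next to a carbonyl group stays within the scatter (a 1.3-fold lower number from compound 1 to compound 3 (0.12 log units; within the scatter)). No measured evidence bears on why.

As far as these compounds go, whether a longer chain than that of compound 3 would lower the number further remains open. So does how an amine or a carboxylic acid in place of hexyl would read.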